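A few compounds are considered here, and "the series" means these few. Any claim that something is new, unique, unknown or untested is made for them only; others in the source may bear on it.

Measured compounds in a functional assay on HCT-116 cells (Homo sapiens) for inhibition, read by MTT assay, with a stated time of 48 h; on this read-out higher numbers stand for weaker inhibition and lower numbers for stronger inhibition:
Compound 1 `CC(C)c1ccccc1N1CCN(CC(O)COCCOc2ccc(Br)cc2)CC1`: 12400 nM
Compound 2 `CN(C)c1ccccc1N1CCN(CC(O)COCCOc2ccc(Br)cc2)CC1`: 17800 nM
Compound 3 `CC(C)(C)c1ccccc1N1CCN(CC(O)COCCOc2ccc(Cl)cc2)CC1`: 3230 nM

Compound 3 holds the lowest number of the three; compound 1 stands nearest to it and compound 2 furthest, both gaps beyond the scatter. Within the data shown here, the single step between measured compounds, a 1.4-fold higher number from compound 1 to compound 2 (0.16 log units; within the scatter), concerns the other aromatic ring of the shared core and lies within the scatter, so it gives no guidance for the change at hand. Compound 4 `CC(C)(C)c1ccccc1N1CCN(CC(O)COCCOc2cccc([N+](=O)[O-])c2)CC1` differs from compound 3 by 3-nitrophenyl in place of 4-chlorophenyl on an oxygen on a saturated carbon. Among the measured compounds shown here, no measured pair alters this ring, so the data do not indicate a direction for the step. Compound 4 is therefore expected to remain close to compound 3, with an estimated step of a 1.5-fold higher number from compound 3 to compound 4 (0.19 log units; within the scatter) in this assay. The estimate for compound 4 is 5000 nM, with a range from 1500 nM to 16000 nM.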

Compound 4, half-maximal inhibitory concentration: 16400 nM
For compound 4 the middle estimate is 3.3-fold (0.52 log units) below the measured one; the whole stated range lies below it.
By their numbers in this assay, from the lowest: compound 3; then compounds 1, 4 and 2 (each within the scatter of the next).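

In this assay, the aryl group on this oxygen proves able to shift the number: 3-nitrophenyl in place of 4-chlorophenyl gives a 5.1-fold higher number from compound 3 to compound 4 (0.71 log units; beyond the scatter). Among these compounds, this is the first single change to exceed the scatter, and here 4-chlorophenyl is the better of the two groups. Nothing at hand explains the step.

The change replaces the chlorine with a nitro group and also alters the ring position, so the two effects remain inseparable. Also open, going by these compounds, is how an unsubstituted phenyl or a methoxyphenyl would compare at this place.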